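Working notes: fluoro for chloro, cytotoxicity outlook

The source may report more compounds than this note shows. Statements on the series, on what has been measured and on what is new or still open speak of the compounds shown alone.

Compound 3 `Cc1nc(C(NC(=O)C(=O)Nc2ccc(F)c(Cl)c2)C2CCCCN2)sc1CCO` stands where the whole series stands so far. In an ADME assay on TZM-b1 cells (Homo sapiens) for cytotoxicity, read by XTT assay, with a stated time of 3 days (on this read-out higher numbers stand for lower toxicity in this test and lower numbers for higher toxicity in this test), compound 3 gives only the limit > 75800 nM, a boundary of the test rather than a measured number. Compound 1 `Cc1nc(C(NC(=O)C(=O)Nc2ccc(F)cc2)C2CCCCN2)sc1CCO` in this assay likewise gives only the limit > 88000 nM. Compound 2 `Cc1nc(C(NC(=O)C(=O)NC2CCCCCC2)C2CCCCN2)sc1CCO` in this assay also gives only the limit > 88000 nM. Every value therefore rests on a limit, the limit of > 75800 nM in this assay, at which 1 of the 3 values shown sits, or (the limit of > 88000 nM in this assay, at which 2 of the 3 values shown sit), so the steps a step that the two limits leave unreadable from compound 1 to compound 3, a step that the two limits leave unreadable from compound 1 to compound 2 and a step that the two limits leave unreadable from compound 2 to compound 3 have no readable size or direction.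

Compound 4 `Cc1nc(C(NC(=O)C(=O)Nc2ccc(F)c(F)c2)C2CCCCN2)sc1CCO` differs from compound 3 by fluoro in place of chloro on an aromatic carbon. The step closest in kind is a step that the two limits leave unreadable from compound 1 to compound 3, which touches the same aromatic carbon, but it too is unreadable. Among the compounds with values here, no measured step points to a change beyond the scatter in this assay, and a further limit is the likeliest outcome. Compound 4 is therefore expected to give about 100000 nM in this assay, within 40000 nM to 300000 nM. The expected step is a step that the limit leaves unreadable from compound 3 to compound 4.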

Compound 4, half-maximal cytotoxic concentration: > 78200 nM
Compound 4: only a limit was reported (the forecaster's own chance of this, stated with the estimate: 85%); the middle value is on the limit's open side.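

In this assay compound 4 gives > 78200 nM, a limit and not a number. Within the data shown here, no step to compound 4 from compound 1, compound 2 or compound 3 can be read. The compounds shown leave open whether any of these changes alters cytotoxicity in this assay.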